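Three Esters at the Limit and a Chloro Analogue

The compounds below may be only part of what the source reports. "The series", "measured", "known", "first", "only" and "open" are said of these compounds alone.

Compound 1, `O=C(Oc1ccc(Br)cc1C(=O)Nc1ccc(C(F)(F)F)cc1)c1ccc(Br)cc1`, in an ADME assay on HepG2 cells (Homo sapiens) for cytotoxicity, read by MTT assay, with a stated time of 72 h; a lower number here means a stronger inhibitor, a higher number a weaker inhibitor: the value for compound 1 is the assay limit of > 50000 nM.
Compound 2, `Cc1ccc(C(=O)Oc2ccc(Cl)cc2C(=O)Nc2ccc(C(F)(F)F)cc2)cc1`, in this assay: the value for compound 2 is the assay limit of > 50000 nM.
Compound 3, `O=C(Oc1ccc(Br)cc1C(=O)Nc1ccc(C(F)(F)F)cc1)c1ccc([N+](=O)[O-])cc1`, in this assay: the value for compound 3 is the assay limit of > 50000 nM.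

Compound 3 stands where every measured compound in this set stands, at the limit described by the limit of > 50000 nM in this assay, at which 3 of the 3 values shown sit. No number is known for it, only that limit.

Compound 4, `O=C(Oc1ccc(Cl)cc1C(=O)Nc1ccc(C(F)(F)F)cc1)c1ccc([N+](=O)[O-])cc1`, differs from compound 3 in one place: chloro in place of bromo on an aromatic carbon.

For the measured compounds named here, only one measured step touches this region of the core, a step that the two limits leave unreadable from compound 1 to compound 3, and since both ends of it are limits, its size cannot be read. Compound 2 also carries a chloro group, and its value in this assay is likewise a limit. The data therefore give no direction for the change to compound 4, only three limits in a row.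

Compound 4 is expected to remain at the limit as well, with an estimated step that the limit leaves unreadable from compound 3 to compound 4 from compound 3. The estimate for compound 4 in this assay is 80000 nM, within a range from 30000 nM to 300000 nM, and the likeliest outcome is that the assay again reports only a limit.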

Compound 4, half-maximal inhibitory concentration: > 50000 nM
Compound 4: only a limit was reported; the forecaster's own chance of this, stated with the estimate: 85%; the middle value does not contradict the limit.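

Compound 4 also gives only a limit, and the steps to it from compound 2 and compound 3 cannot be read, as every value shown is a limit: the limit of > 50000 nM in this assay, at which 4 of the 4 values shown sit.

The compounds shown leave open whether any change to the shared core would give a readable number in this assay.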